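Adding a Second Nitro Group to Compound 3

This account rests on a few compounds, and the source may have more. Where it says the series, first, only, none or still open, it means among the compounds named here.

Compound 1 `O=c1cc(/C=N\c2ccc(O)cc2)c2ccc(OCc3ccccc3)cc2o1`, compound 2 `Nc1ccccc1/N=C\c1cc(=O)oc2cc(OCc3ccccc3)ccc12` and compound 3 `O=c1cc(/C=N\Nc2ccc([N+](=O)[O-])cc2)c2ccc(OCc3ccccc3)cc2o1` share one core and differ only in the group carried by the double-bonded nitrogen. In a functional assay, read by spectrophotometry, with a stated time of 1 h (on this read-out lower numbers stand for stronger inhibition and higher numbers for weaker inhibition), compound 1 gives 233000 nM. In this assay compound 2 gives 34600 nM, and a 6.7-fold lower number from compound 1 to compound 2 (0.83 log units; beyond the scatter). For compound 3 this assay reports only a limit, > 2000000 nM, so its true number is not known. Measured against the other two, compound 3 sits at the weak end: an at least 8.5-fold higher number from compound 1 to compound 3 (0.93 log units; beyond the scatter) and an at least 57-fold higher number from compound 2 to compound 3 (1.76 log units; beyond the scatter), with compound 3 stopping at the limit of > 2000000 nM in this assay, at which 1 of the 3 values shown sits.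

Compound 4 `O=c1cc(/C=N\Nc2ccc([N+](=O)[O-])cc2[N+](=O)[O-])c2ccc(OCc3ccccc3)cc2o1` is not yet measured. It differs from compound 3 in one place: nitro in place of hydrogen on an aromatic carbon. Within the data shown here, no measured step changes the same position, so the expectation rests on where compound 3 already stands, at the limit of this assay. Among the measured compounds shown here, both steps leading to compound 3 weakened inhibition, and nothing among the measured compounds suggests a further nitro would reverse this. The expected step is a step that the limit leaves unreadable from compound 3 to compound 4, meaning none beyond the scatter. Compound 4 is expected to give about 3000000 nM in this assay, within a range of 1000000 nM to 10000000 nM, and most likely to be reported again only as a limit.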

Compound 4, half-maximal inhibitory concentration: 1970000 nM
The estimate for compound 4 lay 1.5-fold (0.18 log units) above the measured number, and the stated range covers the measured number.
By their numbers in this assay, from the lowest: compound 2; then compound 1; then compound 4. At a limit, above all of these: compound 3.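

In this assay, the added nitro, on an aromatic carbon ortho to a large group and meta to a nitro group, gives a true reading: compound 4 gives 1970000 nM. Compound 3 has only a limit, > 2000000 nM. The change shows up as an at least 1.0-fold lower number from compound 3 to compound 4 (0.00 log units; that floor lies within the scatter), so the data cannot say whether this nitro strengthens inhibition, weakens it or leaves it unchanged, and the comparison is bounded by a single value: the limit of > 2000000 nM in this assay, at which 1 of the 4 values shown sits.

Among these compounds, whether this aromatic carbon influences inhibition at all therefore remains open, since the only step at this position starts from a limit. From the compounds shown here alone, how an amine or a methoxy group on the same carbon would compare with the nitro of compound 4 also remains unknown.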